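Pyridin-2-yl to furan-2-yl on the shared core

The source may hold more compounds than are shown below. What is called first, only, known or untested is meant among the compounds shown, and "the series" means these compounds.

Measured compounds:
compound 1 `Oc1ccc(-c2cc(-c3cccc(Cl)c3)nc(-c3ccccn3)c2)cc1` 59.4%
compound 2 `Oc1cccc(-c2cc(-c3cccc(Cl)c3)nc(-c3ccccn3)c2)c1` 0.4%
compound 3 `Oc1ccc(-c2cc(-c3ccc(Cl)cc3)nc(-c3ccccn3)c2)cc1` 12.7%

In an assay on isolated protein for inhibition of DNA topoisomerase 1 (Homo sapiens), with a stated time of 30 min, tested at 100 uM (on this read-out higher numbers stand for a stronger effect at the one concentration tested and lower numbers for a weaker effect), compound 1 gives 59.4%, the highest of the three numbers. Compound 3 comes nearest, and compound 2 lies furthest off. Both measured steps away from compound 1 are large: a number 59 percentage points lower from compound 1 to compound 2 (beyond the scatter) with 3-hydroxyphenyl in place of 4-hydroxyphenyl, and a number 46.7 percentage points lower from compound 1 to compound 3 (beyond the scatter) with 4-chlorophenyl in place of 3-chlorophenyl. Each of these beyond-scatter drops touches one of the two phenyl groups on the core of compound 1.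

Compound 4 `Oc1ccc(-c2cc(-c3cccc(Cl)c3)nc(-c3ccco3)c2)cc1` has not yet been measured in this assay. The change is furan-2-yl in place of pyridin-2-yl on an aromatic carbon. Among the measured compounds shown here, neither measured step concerns this position, so no step bears directly on it; the two measured steps only show that this core tolerates changes poorly so far. The step is expected to lower the read-out, but its size is open: a number 29.4 percentage points lower from compound 1 to compound 4 (beyond the scatter) is the expected step. Compound 4 is estimated at 30%, within 5% to 60%, in this assay.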

Compound 4, a percentage reported as inhibition, at one concentration (the size of the read-out at that concentration, not a potency): 25.5%
Compound 4: middle estimate off by 4.5 percentage points, on the high side, and the stated range covers the measured number.
By their numbers in this assay, from the lowest: compound 2; then compound 3; then compound 4; then compound 1.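

In this assay, furan-2-yl in place of pyridin-2-yl gives a number 33.9 percentage points lower from compound 1 to compound 4 (beyond the scatter), so this position, next to the ring nitrogen, also affects the read-out, and a change at either phenyl group is no longer the only kind shown to do so. The loss occurs although the two groups match in their counts of hydrogen-bond donors and acceptors and neither carries a net charge; those counts alone therefore do not account for the read-out here. The swap alters ring size and hetero atom together, so this single step cannot assign the loss to either change, and no available measurement explains it.

Still open, as far as these compounds go, is which of the two changes matters: phenyl would remove the ring nitrogen while keeping the six-membered ring, and pyrrol-2-yl or thiophen-2-yl would vary the hetero atom within a five-membered ring. Among the compounds shown, furan-2-yl occurs only with the 3-chlorophenyl and 4-hydroxyphenyl groups, so it remains unknown whether the step would carry over to the 3-hydroxyphenyl or 4-chlorophenyl partners.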